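The source may report more compounds than this note shows. Statements on the series, on what has been measured and on what is new or still open speak of the compounds shown alone.

Notes on the series. In an ADME assay on Huh-5-2 cells (Homo sapiens) for cytotoxicity (a lower number here means that less compound is tolerated, a higher number that more compound is tolerated), compound 2 `Cc1ccc(C#Cc2nc(C(N)=O)nn2COCCO)cc1` gives > 50 ug/mL, which is a limit of the assay and not a number. Compound 1 `COc1ccc(C#Cc2nc(C(N)=O)nn2COCCO)cc1` also sits at a limit in this assay, at > 50 ug/mL. Compound 3 `NC(=O)c1nc(C#Cc2ccc(C(F)(F)F)cc2)n(COCCO)n1` gives 20 ug/mL in this assay. Between two limits there is nothing to read: a step that the two limits leave unreadable from compound 1 to compound 2. The readable steps are an at least 2.5-fold lower number from compound 1 to compound 3 (0.39 log units; beyond the scatter) and an at least 2.5-fold lower number from compound 2 to compound 3 (0.39 log units; beyond the scatter), each a swap of one substituent on the aromatic ring for trifluoromethyl. Compound 4 `NC(=O)c1nc(C#CC2(O)CCCC2)n(COCCO)n1` differs from compound 2 by 1-hydroxycyclopentyl in place of 4-methylphenyl on a triple-bonded carbon. Among the compounds with values here, none of the measured steps touches this change: all of them alter a substituent on the six-membered aromatic ring, whereas compound 4 removes that ring altogether and brings in a hydrogen-bond donor. With the limit of > 50 ug/mL in this assay, at which 2 of the 3 values shown sit, as the only anchor, compound 4 is expected to stay near that limit, so a step that the limit leaves unreadable from compound 2 to compound 4 is expected to remain within the scatter. The estimate for compound 4 is therefore 60 ug/mL, with a range from 25 ug/mL to 120 ug/mL, and most likely a limit again rather than a number.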

Compound 4, half-maximal cytotoxic concentration: > 50 ug/mL
Compound 4: no number, only a limit; the forecaster's own chance of this, stated with the estimate: 70%; the middle value does not contradict the limit.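

Compound 2 and compound 4 each give only a limit of the assay, so the step between them cannot be read. The compounds shown leave open whether the number in this assay differs at all with 1-hydroxycyclopentyl in place of 4-methylphenyl on a triple-bonded carbon.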